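Cytotoxicity notes: the step from compound 3 to compound 4

The source may hold more compounds than are shown below. What is called first, only, known or untested is meant among the compounds shown, and "the series" means these compounds.

In an ADME assay on RAW264.7 cells (Mus musculus) for cytotoxicity, read by flow cytometry and propidium iodide staining (on this read-out lower numbers stand for stronger inhibition and higher numbers for weaker inhibition), compound 1 `C=CCc1ccc(OC(C)C)c(-c2ccc(OC)c(CC=C)c2)c1` gives > 100000 nM, a limit of the assay. Compound 2 `C=CCNC(=O)Oc1ccc(CC=C)cc1-c1ccc(OC)c(CC=C)c1` gives > 100000 nM, also a limit. Among the compounds with values here, compound 3 `C=CCc1ccc(O)c(-c2cc(CCC)on2)c1` gives 81000 nM, the only actual number so far. Compound 4 `C=CCc1ccc(O)c(-c2cc(CO)on2)c1` differs from it by hydroxy in place of ethyl on a saturated chain carbon bound to an aromatic carbon, or propyl to hydroxymethyl. Within the data shown here, the one measured step, a step that the two limits leave unreadable from compound 1 to compound 2, changes another place and gives no size to carry over. Compound 3 already lies near the limit reached by the other two, so only a small move is foreseen. The expected step in this assay is a 1.4-fold higher number from compound 3 to compound 4 (0.13 log units; within the scatter), small and towards weaker inhibition. Compound 4 is estimated at 110000 nM, within 50000 nM to 250000 nM.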

Compound 4, half-maximal inhibitory concentration: > 50000 nM
Compound 4: no number, only a limit; the forecaster's own chance of this, stated with the estimate: 60%; the middle value lies beyond the limit too.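

No step can be read from compound 3 to compound 4, since compound 4 gives only a limit, > 50000 nM. The compounds shown leave open how far propyl to hydroxymethyl actually moves the value in this assay.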